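The source may hold more compounds than are shown below. What is called first, only, known or untested is meant among the compounds shown, and "the series" means these compounds.

Measured so far:
compound 1, `Cc1c(NC(=O)c2ccc(C(C)(C)C)cc2)cccc1-c1ccnc2[nH]c(-c3ccc(C(=O)N4CCOCC4)cc3)nc12`: 0.02 10^-6 cm/s
compound 2, `Cn1cc(-c2nc3c(-c4ccc(CNC(=O)c5ccc(C(C)(C)C)cc5)c(F)c4)ccnc3[nH]2)cn1`: 0.4 10^-6 cm/s

In an ADME assay on Caco-2 cells (Homo sapiens) for permeability, in the apical to basolateral direction (a lower number here means that the compound crosses the layer more slowly, a higher number that the compound crosses the layer faster), compound 2 gives 0.4 10^-6 cm/s, the higher of the two numbers; compound 1 gives 0.02 10^-6 cm/s, a gap beyond the scatter. For the measured compounds named here, no measured pair differs in one place, so no single change has a known step yet. Compound 3 `Cn1cc(-c2nc3c(-c4ccc(CNC(=O)c5noc(C(C)(C)C)n5)c(F)c4)ccnc3[nH]2)cn1` differs from compound 2 by 5-(tert-butyl)-1,2,4-oxadiazol-3-yl in place of 4-(tert-butyl)phenyl on a carbonyl carbon. Going by the values given here, no measured step covers this change; for a 1.3-fold lower number from compound 2 to compound 3 (0.12 log units; within the scatter) a move within the scatter or a modest shift downward is expected. Compound 3 is accordingly estimated at 0.3 10^-6 cm/s, range 0.1 10^-6 cm/s to 1 10^-6 cm/s.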

Compound 3, apparent permeability: 2.5 10^-6 cm/s
The estimate for compound 3 lay 8.3-fold (0.92 log units) below the measured number, outside the stated range (above it).
By their numbers in this assay, from the lowest: compound 1; then compound 2; then compound 3.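

In this assay, for the compounds shown here, the change from 4-(tert-butyl)phenyl to 5-(tert-butyl)-1,2,4-oxadiazol-3-yl on a carbonyl carbon gives a 6.3-fold higher number from compound 2 to compound 3 (0.80 log units; beyond the scatter) and so provides the first single-place step. It shows that this position alone can move the number beyond the scatter, with tert-butyl present on both rings. No measurement shown gives a reason for the step.

From the compounds shown here alone, whether a pyridine ring on this carbonyl carbon would move the number in the same direction remains open. So does whether the step holds with cyclopropyl in place of tert-butyl on the oxadiazole ring.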